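Hydroxy to bromo on the benzylidene ring of compound 1

The source may report more compounds than this note shows. Statements on the series, on what has been measured and on what is new or still open speak of the compounds shown alone.

Measured compounds:
compound 1 `O=C(O)c1ccc(C(=O)/C(=C\c2ccc(O)c([N+](=O)[O-])c2)SCc2ccc(Br)cc2)cc1`, 50000 nM
compound 2 `O=C(/C(=C\c1ccc(O)c([N+](=O)[O-])c1)SCc1ccc(Br)cc1)c1ccc(Cl)cc1Cl`, 10000 nM
compound 3 `O=C(/C(=C\c1ccc(O)c([N+](=O)[O-])c1)SCc1ccc(Br)cc1)c1ccc(O)cc1O`, a limit, > 100000 nM

In a functional assay on DU-145 cells (Homo sapiens) for inhibition, read by trypan blue exclusion, with a stated time of 96 h (a lower number here means a stronger inhibitor of growth, a higher number a weaker inhibitor of growth), compound 1 gives 50000 nM, the higher of the two numbers in hand. The nearest number belongs to compound 2, reached by a 5.0-fold lower number from compound 1 to compound 2 (0.70 log units; beyond the scatter). Compound 3 gives only a limit in this assay, > 100000 nM; its value sits at the limit of > 100000 nM in this assay, at which 1 of the 3 values shown sits. From compound 2 the series shows an at least 10-fold higher number from compound 2 to compound 3 (1.00 log units; beyond the scatter), and from compound 1 it shows an at least 2.0-fold higher number from compound 1 to compound 3 (0.30 log units; that floor lies within the scatter).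

Compound 4 `O=C(O)c1ccc(C(=O)/C(=C\c2ccc(Br)c([N+](=O)[O-])c2)SCc2ccc(Br)cc2)cc1` differs from compound 1 by bromo in place of hydroxy on an aromatic carbon. Every measured step in this set changes the aryl group on the carbonyl carbon and leaves the 4-hydroxy-3-nitrophenyl ring untouched, so none of them bears directly on this change. Without a measured precedent on that ring, no step beyond the scatter is assumed in either direction; the estimate stays close to compound 1, with a wide range to admit a modest shift either way. The expected step is no change at the digits printed from compound 1 to compound 4 (within the scatter). Compound 4 is expected to give about 50000 nM in this assay, estimated between 15000 nM and 150000 nM.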

Compound 4, concentration for 50% growth inhibition in the DU-145 assay: 1000 nM
Estimate against measurement, compound 4: 50-fold (1.70 log units) above; the measured number lies below the stated range.
By their numbers in the DU-145 assay, from the lowest: compound 4; then compound 2; then compound 1. At a limit, above all of these: compound 3.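

Within the data shown here, in the DU-145 assay, the earlier steps all changed the aryl group on the carbonyl carbon, whereas a 50-fold lower number from compound 1 to compound 4 (1.70 log units; beyond the scatter) shows that the 4-hydroxy-3-nitrophenyl ring is also a site of large change, with the 4-carboxyphenyl group held constant. Replacing hydroxy with bromo ortho to the nitro group gives a stronger inhibitor of growth in this pair, but nothing measured here gives a cause for that step. In a physicochemical assay for solubility (a lower number here means a less soluble compound, a higher number a more soluble compound), compound 1 gives only a limit, < 1000 ug/mL. In the physicochemical assay, compound 4 also gives only a limit, < 1000 ug/mL. In the physicochemical assay, the step from compound 1 to compound 4 cannot be read, as both compounds stand at a limit: the limit of < 1000 ug/mL in the physicochemical assay, at which 2 of the 2 values shown sit.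

On these data alone, it remains open whether the gain belongs to bromo itself or would also appear with another group at this position, such as chloro, methoxy or an amine. As far as these compounds go, it also remains open whether the same change would give a step of similar size on compound 2, which carries 2,4-dichlorophenyl in place of 4-carboxyphenyl on the carbonyl carbon.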